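Swapping Hydroxy for Fluoro on the Aromatic Ring

This account rests on a few compounds, and the source may have more. Where it says the series, first, only, none or still open, it means among the compounds named here.

In a functional assay on PC-3 cells (Homo sapiens) for cytotoxicity (a higher number here means that more compound is needed for the effect, a lower number that less compound is needed), compound 1 `COC1=C(C)C(=O)/C(=C(O)/C=C/c2ccc(OC)cc2)C(=O)C1(C)C` gives 18.2 ug/mL. Compound 2 `COC1=C(C)C(=O)/C(=C(O)/C=C/c2ccc(O)cc2)C(=O)C1(C)C` gives > 20 ug/mL, which is a limit of the assay and not a number. Compound 3 `COC1=C(C)C(=O)/C(=C(O)/C=C/c2ccc(F)cc2)C(=O)C1(C)C` keeps the shared core of compound 2 but carries fluoro in place of hydroxy on an aromatic carbon. Within the data shown here, only one measured step concerns this part of the molecule, with hydrogen in place of methyl on an oxygen on an aromatic ring: an at least 1.0-fold higher number from compound 1 to compound 2 (0.04 log units; that floor lies within the scatter). That single step offers no sign of a large change at this spot, so no step beyond the scatter is expected in this assay. The expected change is an at least 1.1-fold lower number from compound 2 to compound 3 (0.04 log units; that floor lies within the scatter). For compound 3 the estimate is 18 ug/mL, with an expected range from 8 ug/mL to 35 ug/mL.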

Compound 3, concentration for half-maximal effect: 7.2 ug/mL
Compound 3: middle estimate off by 2.5-fold (0.40 log units), on the high side, outside the stated range (below it).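

Until now, this position on the aromatic ring had shown no step beyond the scatter, but in this assay the change to fluoro shows that it can move the read-out. Against methoxy there is a 2.5-fold lower number from compound 1 to compound 3 (0.40 log units; beyond the scatter), and against hydroxy there is an at least 2.7-fold lower number from compound 2 to compound 3 (0.44 log units; beyond the scatter); the second step gives only the smallest change the data allow. For compound 2 the assay gives only a limit, not a number: the limit of > 20 ug/mL in this assay, at which 1 of the 3 values shown sits.

From the compounds shown here alone, how chloro, an amine or a carboxylic acid would read at this same place on the ring remains open. Also open, going by these compounds, is whether fluoro would give a similar step if the methoxy on the shared core were replaced by a longer chain such as ethoxy.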